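The source may hold more compounds than are shown below. What is called first, only, known or untested is meant among the compounds shown, and "the series" means these compounds.

Compounds measured so far in an assay on CHO cells for antagonist activity at transient receptor potential cation channel subfamily V member 1 (Homo sapiens), read by FLIPR and calcium flux; a higher number here means a weaker inhibitor, a lower number a stronger inhibitor:
Compound 1, `CC(C(=O)NCc1ccc(C(F)(F)F)nc1Cl)c1ccc(NS(C)(=O)=O)c(F)c1`, gives 0.2 nM.
Compound 2, `CCCCCCc1nc(C(F)(F)F)ccc1CNC(=O)C(C)c1ccc(NS(C)(=O)=O)c(F)c1`, gives 1.6 nM.
Compound 3, `CCC1CCC(c2nc(C(F)(F)F)ccc2CNC(=O)[C@@H](C)c2ccc(NS(C)(=O)=O)c(F)c2)CC1`, gives 0.2 nM.

Among these three, compound 2 has the highest number in this assay; compound 1 and compound 3 both stand at the same lower value, and each gap to compound 2 lies beyond the scatter. For the measured compounds named here, the only single-point step that leads to compound 2 is an 8.0-fold higher number from compound 1 to compound 2 (0.90 log units; beyond the scatter), hexyl in place of chloro on an aromatic carbon. Compound 3 carries a ring on that carbon instead of the hexyl chain and differs from compound 2 in more than one place, so only the two values are compared: compound 3 matches compound 1.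

Compound 4, `CC(C(=O)NCc1ccc(C(F)(F)F)nc1C1CCC(C)(C)CC1)c1ccc(NS(C)(=O)=O)c(F)c1`, has not yet been measured. Its change from compound 2 is 4,4-dimethylcyclohexyl in place of hexyl on an aromatic carbon. The step bears on the same aromatic carbon as the step from compound 1 to compound 2, and compound 3, with a ring in that place, gives 0.2 nM. Compound 4 is therefore expected to move back toward the lower values, with an expected step of a 5.3-fold lower number from compound 2 to compound 4 (0.73 log units; beyond the scatter). The estimate for compound 4 is 0.3 nM, with a range from 0.1 nM to 1 nM.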

Compound 4, inhibition constant: 0.4 nM
The estimate for compound 4 lay 1.3-fold (0.12 log units) below the measured number; the measured number falls inside the stated range.
By their numbers in this assay, from the lowest: compounds 1, 3 and 4 (each within the scatter of the next); then compound 2.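

In this assay, the rise seen with hexyl at this aromatic carbon, next to the ring nitrogen, does not simply follow the number of carbons, as the larger 4,4-dimethylcyclohexyl group gives a 4.0-fold lower number from compound 2 to compound 4 (0.60 log units; beyond the scatter), a step beyond the scatter. The replacement of chloro by the same ring gives a 2.0-fold higher number from compound 1 to compound 4 (0.30 log units; within the scatter), which lies within the scatter, so this position accepts either the small halogen or the ring carbocycle without a readable change in this assay, whereas the open hexyl chain stands apart from both. Nothing given here explains why the ring and the chain differ at this carbon.

Compound 2 and compound 4 differ both in the presence of a ring and in their carbon count, so these compounds cannot separate the two, and an octyl chain or an unsubstituted cyclohexyl group at this carbon would be needed to do so. As far as these compounds go, it also remains open how far this acceptance extends beyond groups made only of carbon and halogen, for instance to an amine or a morpholine ring at the same place.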